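A few compounds are considered here, and "the series" means these few. Any claim that something is new, unique, unknown or untested is made for them only; others in the source may bear on it.

Compound 1 `CCOC(=O)C1=C(C)N/C(=N\C#N)NC1c1cccs1` gives 26% in an assay on cells for displacement of a labelled ligand from adenosine receptor A1 (Homo sapiens), with a stated time of 60 min, tested at 1 uM; a higher number here means more inhibition at the concentration tested (going by the name of the read-out), a lower number less inhibition.
Compound 2 `CCOC(=O)C1=C(C)N/C(=N\C#N)NC1c1ccco1` gives 27% in this assay.
Compound 3 `CC1=C(C(=O)OC(C)C)C(c2ccco2)N/C(=N/C#N)N1` gives 21% in this assay.

These three compounds share a core and differ in two places. From compound 2 to compound 1 the change is thiophen-2-yl in place of furan-2-yl on a saturated ring carbon, and the step it made was a number 1 percentage points lower from compound 2 to compound 1 (within the scatter). From compound 2 to compound 3 the change is methyl in place of hydrogen on a saturated chain carbon bound to an oxygen next to a carbonyl group and a saturated chain carbon, and the step was a number 6 percentage points lower from compound 2 to compound 3 (within the scatter). Compound 3 has the lowest of the three numbers, but its gaps to compound 1 and to compound 2 both lie within the scatter, so no order among the three can be read from these values.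

Compound 4 `CC1=C(C(=O)OC(C)C)C(c2cccs2)N/C(=N/C#N)N1` has not yet been measured in this assay. It differs from compound 3 by thiophen-2-yl in place of furan-2-yl on a saturated ring carbon. Among the compounds with values here, this is the same kind of change as the one from compound 2 to compound 1, but not the same: around the place, compound 3 and compound 4 carry an isopropoxycarbonyl group (6 heavy atoms) where compound 2 and compound 1 carry an ethoxycarbonyl group (5 heavy atoms), a difference in the core that methyl in place of hydrogen on a saturated chain carbon bound to an oxygen next to a carbonyl group and a saturated chain carbon describes. Because the earlier step of a number 1 percentage points lower from compound 2 to compound 1 (within the scatter) lay within the scatter, the step from compound 3 to compound 4 is expected to be small as well, a number 1 percentage points lower from compound 3 to compound 4 (within the scatter). Within the data shown here, compound 4 is therefore estimated at 20%, with the likely range 10% to 30%, resting on the value of compound 3, 21%, and on the single earlier step of this kind.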

Compound 4, a percentage reported as inhibition, at one concentration (the size of the read-out at that concentration, not a potency): 31%
For compound 4 the middle estimate is 11 percentage points below the measured one, outside the stated range (above it).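

Set on the core of compound 3, which carries an isopropoxycarbonyl group, thiophen-2-yl in place of furan-2-yl gave a number 10 percentage points higher from compound 3 to compound 4 (within the scatter), and this step does not differ from the earlier one on the ethoxycarbonyl core: the same change on two cores in this assay, a number 1 percentage points lower (within the scatter) from compound 2 to compound 1 and a number 10 percentage points higher (within the scatter) from compound 3 to compound 4, 11 percentage points apart, within the scatter of two such steps

Methyl in place of hydrogen on the saturated chain carbon bound to the ester oxygen, now read on the thiophen-2-yl compounds, gave a number 5 percentage points higher from compound 1 to compound 4 (within the scatter), and this step also agrees with its earlier counterpart: the same change on two cores in this assay, a number 6 percentage points lower (within the scatter) from compound 2 to compound 3 and a number 5 percentage points higher (within the scatter) from compound 1 to compound 4, 11 percentage points apart, within the scatter of two such steps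

In this assay, neither change is thus shown to depend on the core, but this does not show that either carries over unaltered, since each step and each gap between steps lies within the scatter, so these four compounds can neither reveal nor exclude an effect of either change or an interplay between the two.

The compounds shown leave open what a phenyl or a pyridyl ring on the saturated ring carbon would give in this assay, and likewise a carboxylic acid or an amide in place of the ester. They also leave open how a longer chain on the ester oxygen would compare with the ethoxycarbonyl and isopropoxycarbonyl groups.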